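Notes on the step from compound 3 to compound 4

The source may report more compounds than this note shows. Statements on the series, on what has been measured and on what is new or still open speak of the compounds shown alone.

In a functional assay on SK-OV-3 cells (Homo sapiens) (a lower number here means a stronger inhibitor of growth, a higher number a weaker inhibitor of growth), compound 1 (`O=S(=O)(/C=C/c1ccc(Cl)cc1)Cc1ccc(Nc2ncnc3ccccc23)cc1`) gives 54000 nM, compound 2 (`O=S(=O)(/C=C/c1ccc(F)cc1F)Cc1ccc(Nc2ncnc3ccccc23)cc1`) gives 69000 nM and compound 3 (`O=S(=O)(/C=C/c1ccc(F)cc1Cl)Cc1ccc(Nc2ncnc3ccccc23)cc1`) gives 44000 nM. Compound 3 stands level with the other two, with every gap among the three within the scatter.

Compound 4 (`O=S(=O)(/C=C/c1ccc(C(F)(F)F)cc1F)Cc1ccc(Nc2ncnc3ccccc23)cc1`) is the next change at the same place: 2-fluoro-4-(trifluoromethyl)phenyl in place of 2-chloro-4-fluorophenyl on a double-bonded chain carbon bound to a double-bonded chain carbon. It carries 2-fluoro-4-(trifluoromethyl)phenyl in place of 2-chloro-4-fluorophenyl, on a double-bonded chain carbon bound to a double-bonded chain carbon.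

Three measured steps at this place bear on it: a 1.3-fold higher number from compound 1 to compound 2 (0.11 log units; within the scatter), a 1.2-fold lower number from compound 1 to compound 3 (0.09 log units; within the scatter) and a 1.6-fold lower number from compound 2 to compound 3 (0.20 log units; within the scatter). All three stay within the scatter. Among the compounds with values here, no measured compound carries trifluoromethyl, so the data do not test that group directly, and they give no direction for the change.

No step beyond the scatter is expected in this assay. The expected change is a 1.1-fold higher number from compound 3 to compound 4 (0.06 log units; within the scatter). For compound 4 the estimated value is 50000 nM, with an expected range of 25000 nM to 100000 nM.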

Compound 4, concentration for 50% growth inhibition: 39000 nM
For compound 4 the middle estimate is 1.3-fold (0.11 log units) above the measured one; the range from low to high includes it.
By their numbers in this assay, from the lowest: compounds 4, 3, 1 and 2 (each within the scatter of the next).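

Trifluoromethyl now has a direct reading at this place in this assay and brings a 1.1-fold lower number from compound 3 to compound 4 (0.05 log units; within the scatter) together with a 1.8-fold lower number from compound 2 to compound 4 (0.25 log units; within the scatter) and a 1.4-fold lower number from compound 1 to compound 4 (0.14 log units; within the scatter) so that no step in the series leaves the scatter. With 11 heavy atoms entering in place of 8, the change on a double-bonded chain carbon bound to a double-bonded chain carbon still leaves compound 4 level with compounds 1, 2 and 3. The phenyl groups shown therefore remain indistinguishable in this assay.

As far as these compounds go, all four phenyl groups carry only halogen or trifluoromethyl, so it stays open whether an amine or a carboxylic acid on that ring would shift the number beyond the scatter. The same holds for a longer chain in place of the phenyl group. No measured evidence accounts for this flat result.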